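A few compounds are considered here, and "the series" means these few. Any claim that something is new, unique, unknown or untested is made for them only; others in the source may bear on it.

In a functional assay on HepG2 cells (Homo sapiens) for antiproliferative activity, read by MTT assay, with a stated time of 48 h (a higher number here means a weaker inhibitor, a lower number a stronger inhibitor), compound 1 `O=C(Nc1ccccc1)Nc1nnc(Sc2ncnc3scc(-c4ccncc4)c23)s1` gives 19400 nM, and compound 2 `Cc1ccc(NC(=O)Nc2nnc(Sc3ncnc4scc(-c5ccncc5)c34)s2)cc1Cl` gives 16000 nM; compound 2 thus holds the lowest of the two numbers, yet the step of a 1.2-fold lower number from compound 1 to compound 2 (0.08 log units; within the scatter) stays within the scatter. Compound 3 `COc1ccc(NC(=O)Nc2nnc(Sc3ncnc4scc(-c5ccncc5)c34)s2)cc1` differs from compound 2 by 4-methoxyphenyl in place of 3-chloro-4-methylphenyl on an amide-type nitrogen. Among the compounds with values here, the only measured step bearing on this position, a 1.2-fold lower number from compound 1 to compound 2 (0.08 log units; within the scatter), was small, so no step beyond the scatter is expected for compound 3 in this assay, in either direction. Compound 3 is therefore estimated at 18000 nM, with a range from 8000 nM to 40000 nM, which would be a step of a 1.1-fold higher number from compound 2 to compound 3 (0.05 log units; within the scatter).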

Compound 3, half-maximal inhibitory concentration: 14600 nM
For compound 3 the middle estimate is 1.2-fold (0.09 log units) above the measured one, and the stated range covers the measured number.
By their numbers in this assay, from the lowest: compounds 3, 2 and 1 (each within the scatter of the next).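

In this assay, replacing a chlorine-bearing aryl group with an oxygen-bearing one on the amide-type nitrogen gives a 1.1-fold lower number from compound 2 to compound 3 (0.04 log units; within the scatter). Adding methoxy to the unsubstituted phenyl gives a 1.3-fold lower number from compound 1 to compound 3 (0.12 log units; within the scatter), so none of the three groups at this position can be told apart from the others. No evidence is available to explain this result. The compounds shown leave open whether an amine or a carboxylic acid on this phenyl, or a longer chain in its place, would give a step beyond the scatter.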